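Naphthalenyl Sulfonamide Change Carried to the Chloro Analogue

The compounds below may be only part of what the source reports. "The series", "measured", "known", "first", "only" and "open" are said of these compounds alone.

Three compounds sharing one core were tested for cytotoxicity: compound 1 `COc1ccc(S(=O)(=O)NCCCNc2nccc(-c3[nH]c(-c4ccccc4)nc3-c3ccc(F)c(O)c3)n2)cc1`, compound 2 `O=S(=O)(NCCCNc1nccc(-c2[nH]c(-c3ccccc3)nc2-c2ccc(F)c(O)c2)n1)c1cccc2ccccc12` and compound 3 `COc1ccc(S(=O)(=O)NCCCNc2nccc(-c3[nH]c(-c4ccccc4)nc3-c3ccc(Cl)c(O)c3)n2)cc1`. In a functional assay on LOX IMVI cells (Homo sapiens) for cytotoxicity, read by MTT assay, with a stated time of 24 h (a higher number here means a weaker inhibitor, a lower number a stronger inhibitor), compound 1 gives 13900 nM, compound 2 gives 3710 nM, and compound 3 gives 36800 nM. The difference between compound 1 and compound 2 is naphthalen-1-yl in place of 4-methoxyphenyl on a sulfonyl sulfur, and it produced a 3.7-fold lower number from compound 1 to compound 2 (0.57 log units; beyond the scatter). The two cores differ as described by chloro in place of fluoro on an aromatic carbon, which produced a 2.6-fold higher number from compound 1 to compound 3 (0.42 log units; beyond the scatter). Compound 4 `O=S(=O)(NCCCNc1nccc(-c2[nH]c(-c3ccccc3)nc2-c2ccc(Cl)c(O)c2)n1)c1cccc2ccccc12` has not yet been measured; it differs from compound 3 by naphthalen-1-yl in place of 4-methoxyphenyl on a sulfonyl sulfur, the same change at the same place as seen between compound 1 and compound 2. In this assay, among the compounds with values here, compound 4 is expected to show a 3.7-fold lower number from compound 3 to compound 4 (0.57 log units; beyond the scatter), an expectation resting on the single earlier step of a 3.7-fold lower number from compound 1 to compound 2 (0.57 log units; beyond the scatter) on the other core. For compound 4 the estimated value is 10000 nM, between 4000 nM and 25000 nM.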

Compound 4, half-maximal inhibitory concentration: 7720 nM
Compound 4: the middle estimate sits 1.3-fold (0.11 log units) above what was measured, within the range that was stated.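

On the core of compound 3, naphthalen-1-yl in place of 4-methoxyphenyl gave a 4.8-fold lower number from compound 3 to compound 4 (0.68 log units; beyond the scatter), and this step matches the earlier one: the same change on two cores in this assay, a 3.7-fold lower number (0.57 log units; beyond the scatter) from compound 1 to compound 2 and a 4.8-fold lower number (0.68 log units; beyond the scatter) from compound 3 to compound 4, 1.3-fold (0.10 log units) apart, within the scatter of two such steps. Chloro in place of fluoro gave a 2.1-fold higher number from compound 2 to compound 4 (0.32 log units; beyond the scatter), which likewise matches its earlier counterpart: the same change on two cores in this assay, a 2.6-fold higher number (0.42 log units; beyond the scatter) from compound 1 to compound 3 and a 2.1-fold higher number (0.32 log units; beyond the scatter) from compound 2 to compound 4, 1.3-fold (0.10 log units) apart, within the scatter of two such steps. In this assay each change therefore carried over between these two cores, but this rests on only four compounds and does not show that either change would carry over to any other core or into any other assay.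

The compounds shown leave open how bromo in place of chloro, or naphthalen-2-yl in place of naphthalen-1-yl, would behave. They also leave open the effect of a longer chain in place of the one shared here.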